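Nitro in place of chloro: expected shift from compound 2

The source may hold more compounds than are shown below. What is called first, only, known or untested is meant among the compounds shown, and "the series" means these compounds.

For the measured compounds named here, in a physicochemical assay for lipophilicity, measured as octanol-water partition (on this read-out higher numbers stand for higher lipophilicity and lower numbers for lower lipophilicity), compound 2 `CC(C)[C@@H]1CC[C@@H](C)C[C@H]1OC(=O)c1ccc(Cl)cc1` gives 5.34, the second highest of the three numbers measured so far. Compound 1 `CC(C)[C@@H]1CC[C@@H](C)C[C@H]1OC(=O)c1ccc(Cl)cc1Cl` stands higher at 5.86, and compound 3 `CC(Cl)C(=O)O[C@@H]1C[C@H](C)CC[C@H]1C(C)C` stands lower at 4.04. Both gaps from compound 2 lie beyond the scatter.

Compound 4 `CC(C)[C@@H]1CC[C@@H](C)C[C@H]1OC(=O)c1ccc([N+](=O)[O-])cc1` has not been measured and differs from compound 2 in one place: nitro in place of chloro on an aromatic carbon. This is nitro in place of chloro on an aromatic carbon, para to a large group.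

Going by the values given here, only one measured step bears on this change, and only in part. It is a number 0.52 log units lower from compound 1 to compound 2 (beyond the scatter), a modest step beyond the scatter, with hydrogen in place of chloro on an aromatic carbon. Among the compounds with values here, it covers the departure of a chloro but not the arrival of a nitro, since no measured compound carries that group. Compound 3 offers no single-place comparison with compound 2.

Going by the size of a number 0.52 log units lower from compound 1 to compound 2 (beyond the scatter), a modest downward move is expected, though with wide uncertainty. The estimated change is a number 0.64 log units lower from compound 2 to compound 4 (beyond the scatter). In this assay the estimate for compound 4 is 4.7, expected within 4.1 to 5.2.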

Compound 4, partition coefficient: 4.78
Compound 4: the middle estimate sits 0.08 log units below what was measured; the range from low to high includes it.
By their numbers in this assay, from the lowest: compound 3; then compound 4; then compound 2; then compound 1.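

Compound 4 gives the series its first reading for a group other than chloro or hydrogen on this aromatic carbon, para to a large group, and in this assay the swap of chloro for nitro gives a number 0.56 log units lower from compound 2 to compound 4 (beyond the scatter) (with nitro entering with 2 hydrogen-bond acceptors where chloro has 0). For the compounds shown here, until now, the only single-place step involving a chloro was the change to hydrogen, a number 0.52 log units lower from compound 1 to compound 2 (beyond the scatter), which took place on a different compound pair and said nothing about what an incoming group does; both steps are now printed as modest and beyond the scatter, so this part of the core responds measurably to a replacement as well as to a removal. No available evidence accounts for the size or direction of the nitro step.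

On these data alone, whether an amine, a carboxylic acid or a methoxy group on the same aromatic carbon would follow chloro and nitro on this read-out remains open. Going by these compounds alone, also open is whether the nitro step would hold on a different ester, such as the 2-chloropropanoyl side of compound 3, since only one pair carries this swap.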